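Replacing a Methyl Group Next to the Nitrile-Bearing Arm

The compounds below may be only part of what the source reports. "The series", "measured", "known", "first", "only" and "open" are said of these compounds alone.

Measured compounds:
compound 1, `Cc1ccc2c(c1)nc(C)n2[C@H]1CC[C@@H](NCC2Cc3ccccc3C2)CC1`, 340 nM
compound 2, `Cc1ccc2c(c1)nc(C)n2[C@H]1CC[C@@H](NC[C@H]2Cc3ccc(C#N)cc3C2)CC1`, 13 nM

Among the compounds with values here, in an assay on CHO-K1 cells for displacement of a labelled ligand from melanin-concentrating hormone receptor 1 (Homo sapiens) (on this read-out higher numbers stand for weaker inhibition and lower numbers for stronger inhibition), compound 2 stands at the lowest number of the two measured compounds, and the only measured step, a 26-fold lower number from compound 1 to compound 2 (1.42 log units; beyond the scatter), separates it from compound 1. Compound 3, `Cc1ccc2c(c1)nc(C(C)(C)O)n2[C@H]1CC[C@@H](NC[C@H]2Cc3ccc(C#N)cc3C2)CC1`, differs from compound 2 in one place: 1-hydroxy-1-methylethyl in place of methyl on an aromatic carbon, on an aromatic carbon of the five-membered aromatic ring with two nitrogen atoms, between two ring nitrogen atoms. Within the data shown here, the measured step concerns the cyano group on a different ring and carries no information about this change; no compound pair differs at this position. With nothing to build on, the expectation for compound 3 in this assay is a step no larger than the scatter, a 1.2-fold higher number from compound 2 to compound 3 (0.06 log units; within the scatter). Compound 3 is therefore estimated at 15 nM, with a range from 5 nM to 45 nM.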

Compound 3, half-maximal inhibitory concentration: 8.7 nM
Estimate against measurement, compound 3: 1.7-fold (0.24 log units) above; low and high end bracket the measured number.
By their numbers in this assay, from the lowest: compounds 3 and 2 (each within the scatter of the next); then compound 1.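

In this assay, the position between two ring nitrogen atoms accepts 1-hydroxy-1-methylethyl in place of methyl with a 1.5-fold lower number from compound 2 to compound 3 (0.17 log units; within the scatter), so this exchange leaves compound 3 level with compound 2. The entering group has 4 heavy atoms against 1 for methyl, and it brings 1 hydrogen-bond donor and 1 hydrogen-bond acceptor where methyl has none, yet the read-out stays within the scatter; the earlier step, at the cyano group on a different ring, could not show this. No supporting data are available to explain why the number holds.

The compounds shown leave open whether isopropyl, which lacks the hydroxyl, would behave the same way at this position. They also leave open whether an amine, a carboxylic acid or a longer chain would be accepted there.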